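Benzyl(methyl)amino swap in a series at the assay limit

This account rests on a few compounds, and the source may have more. Where it says the series, first, only, none or still open, it means among the compounds named here.

In a functional assay on MCF7 cells (Homo sapiens) for antiproliferative activity, read by MTT assay, with a stated time of 24 h (a higher number here means a weaker inhibitor, a lower number a stronger inhibitor), compound 3 `CCCCNC(=O)CCCOc1ccc(C(=O)c2c(CCCC)oc3ccccc23)cc1` reports only a limit, > 50000 nM. Compound 1 `CCCCc1oc2ccccc2c1C(=O)c1ccc(OCC(=O)NC(C)C)cc1` also reports only a limit, > 50000 nM. Compound 2 `CCCCc1oc2ccccc2c1C(=O)c1ccc(OCC(=O)N2CCCC2)cc1` gives a number, 42400 nM. The picture so far is dominated by the limit of > 50000 nM in this assay, at which 2 of the 3 values shown sit.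

Compound 4 `CCCCc1oc2ccccc2c1C(=O)c1ccc(OCCCC(=O)N(C)Cc2ccccc2)cc1` carries benzyl(methyl)amino in place of butylamino on a carbonyl carbon, so one six-membered aromatic ring of carbon only enters and one hydrogen-bond donor leaves.

Within the data shown here, the closest precedent, also a change on a carbonyl carbon, is an at least 1.1-fold lower number from compound 1 to compound 2 (0.07 log units; that floor lies within the scatter). The other readable step is an at least 1.1-fold higher number from compound 2 to compound 3 (0.07 log units; that floor lies within the scatter), whose floor also lies within the scatter, and the remaining one is a step that the two limits leave unreadable from compound 1 to compound 3. As far as these compounds go, none of these shows a real move in this assay, so no step beyond the scatter is expected, and the direction stays open. The expected step is an at least 1.1-fold lower number from compound 3 to compound 4 (0.04 log units; that floor lies within the scatter). Compound 4 is estimated at 45000 nM, with an expected range of 15000 nM to 90000 nM.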

Compound 4, half-maximal inhibitory concentration: > 50000 nM
Compound 4 was reported as a limit; the forecaster's own chance of this, stated with the estimate: 55%; middle value at least 1.1-fold (0.04 log units) from the limit.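

Compound 3 and compound 4 are both reported only as limits in this assay, so no new step can be read from the benzyl(methyl)amino swap. The compounds shown leave open how benzyl(methyl)amino and butylamino compare on the shared core, with most values resting at one point: the limit of > 50000 nM in this assay, at which 3 of the 4 values shown sit.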